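The source may report more compounds than this note shows. Statements on the series, on what has been measured and on what is new or still open speak of the compounds shown alone.

Compound 1 `CS(=O)(=O)c1ccc(-c2nc3ccccn3c2Sc2ccccc2)cc1`: 13200 nM
Compound 2 `COc1ccc(-c2nc3ccccn3c2Sc2ccccc2)cc1`: 54200 nM
Compound 3 `Cc1ccc(-c2nc3ccc(C)cn3c2Sc2ccccc2)cc1`: 14600 nM

In a functional assay on HepG2 cells (Homo sapiens) for inhibition, read by MTT assay, with a stated time of 48 h (on this read-out lower numbers stand for stronger inhibition and higher numbers for weaker inhibition), compound 2 has the highest of the three numbers, 54200 nM, so it is the weakest of the set. Compound 4 `c1ccc(Sc2c(-c3ccsc3)nc3ccccn23)cc1` is the next to be measured, with thiophen-3-yl in place of 4-methoxyphenyl on an aromatic carbon. Within the data shown here, only one measured step changes this part of the molecule, a 4.1-fold higher number from compound 1 to compound 2 (0.61 log units; beyond the scatter), where methoxy replaces methylsulfonyl on an aromatic carbon. Among the measured compounds shown here, no measured compound carries a thiophene, so this guide is loose. With compound 2 at the top of the range, a modest fall is expected, and the estimated step is a 1.8-fold lower number from compound 2 to compound 4 (0.26 log units; within the scatter). The estimate for compound 4 is 30000 nM, with an expected range of 12000 nM to 70000 nM.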

Compound 4, half-maximal inhibitory concentration: 49600 nM
Compound 4: the middle estimate sits 1.7-fold (0.22 log units) below what was measured, and the stated range covers the measured number.
By their numbers in this assay, from the lowest: compounds 1 and 3 (each within the scatter of the next); then compounds 4 and 2 (each within the scatter of the next).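

In this assay there is a 1.1-fold lower number from compound 2 to compound 4 (0.04 log units; within the scatter) when thiophen-3-yl replaces 4-methoxyphenyl, so this step lies within the scatter. The earlier step changed only a group on the six-membered aromatic ring, whereas this one exchanges that whole ring and its methoxy for a smaller five-membered aromatic ring holding sulfur, with no clear difference in the read-out. No supporting measurement bears on this result.

Going by these compounds, how an amine or a carboxylic acid would behave on this aromatic carbon remains open. So does the effect of placing methylsulfonyl on the thiophene.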